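The compounds below may be only part of what the source reports. "The series", "measured", "known", "first", "only" and "open" are said of these compounds alone.

Of the compounds shown here, three sharing one core have been measured in a functional assay on OVCAR-4 cells (Homo sapiens) for inhibition, read by sulforhodamine B assay, with a stated time of 48 h; a higher number here means a weaker inhibitor of growth, a lower number a stronger inhibitor of growth. Compound 1 `Nc1cc(N)c2nc(-c3ccccc3)c(Oc3ccc(Cl)c(Cl)c3)nc2c1` is reported only as a limit of this assay, at < 100000 nM. That reading sits at the limit of < 100000 nM in this assay, at which 1 of the 3 values shown sits. Compound 2 `CCOC(=O)[C@H](CCC(=O)O)NC(=O)c1ccc(CNc2nc3cc(N)cc(N)c3nc2-c2ccccc2)cc1` gives 79400 nM in this assay. Compound 3 `COc1ccc(CNc2nc3cc(N)cc(N)c3nc2-c2ccccc2)cc1OC` gives 7410 nM in this assay, the lowest of the two numbers shown, with compound 2 standing above it by a gap beyond the usual scatter. Compounds 2 and 3 differ in more than one place, so their two values are simply set side by side.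

The account now turns to compound 4 `COc1ccc(CNc2nc3cc(N)cc(N)c3nc2-c2ccccc2)cc1`, not yet measured in this assay. It differs from compound 3 by hydrogen in place of methoxy on an aromatic carbon, which, cut one bond further out, reads as 3,4-dimethoxyphenyl to 4-methoxyphenyl. Among the measured compounds shown here, no measured pair in this set changes one place only, so there is no measured step on which to base the size of this one. Removing a single methoxy is a small alteration, and compound 4 is expected to stay close to compound 3, with an expected step of a 1.1-fold higher number from compound 3 to compound 4 (0.03 log units; within the scatter) that may well not rise beyond the scatter in either direction. Compound 4 is accordingly estimated at 8000 nM, with a range from 3000 nM to 25000 nM in this assay.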

Compound 4, concentration for total growth inhibition: 21400 nM
For compound 4 the middle estimate is 2.7-fold (0.43 log units) below the measured one; the measured number falls inside the stated range.
By their numbers in this assay, from the lowest: compound 3; then compound 4; then compound 2.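

In this assay the set now holds its first change in one place only: taking away the methoxy that stands ortho to a methoxy group and meta to a large group gives a 2.9-fold higher number from compound 3 to compound 4 (0.46 log units; beyond the scatter), so this place on the aromatic ring is not indifferent to the change. The earlier values could only be set side by side, since compound 2 and compound 3 differ in more than one place, whereas here the 3,4-dimethoxyphenyl group of compound 3 can be compared directly with the 4-methoxyphenyl group of compound 4, and the step, though modest, lies beyond the scatter. Nothing in the data shown accounts for why this step has the size it has.

This single step does not tell whether the lower number of compound 3 belongs to methoxy itself or would also come with a hydroxyl, a chlorine or an ethoxy at the same place. Also open, from the compounds shown here alone, is what a phenyl ring with no methoxy at all would give, and so whether the two methoxy groups add up or act in some other way.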